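The source may hold more compounds than are shown below. What is called first, only, known or untested is meant among the compounds shown, and "the series" means these compounds.

Measured so far in a functional assay on J774 cells (Mus musculus) for cytotoxicity, read by resazurin assay; on this read-out higher numbers stand for weaker inhibition and lower numbers for stronger inhibition:
- compound 1 `O=C(CCCCCO)c1ccc(-c2ccc(F)cc2F)cc1`: 6000 nM
- compound 2 `Cc1cc(-c2ccc(F)cc2F)ccc1C(=O)CCCCCO`: 4000 nM

Only these two numbers exist in the series, and they do not separate. Compound 2, at 4000 nM, stands within the scatter of compound 1, at 6000 nM.

The next structure is compound 3 `O=C(CCCCCO)c1ccc(-c2ccc(F)cc2F)cc1Cl`. Its difference from compound 2 is chloro in place of methyl on an aromatic carbon.

Within the data shown here, one measured step bears on this change: a 1.5-fold lower number from compound 1 to compound 2 (0.18 log units; within the scatter). It concerns the same aromatic carbon, and putting a methyl there left the number within the scatter. Among the measured compounds shown here, no chloro compound has been measured, so the evidence is indirect and rests on a single small step. Nothing in it points to a large move in this assay, and no clear direction can be drawn from it.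

The expected change is a 1.1-fold lower number from compound 2 to compound 3 (0.06 log units; within the scatter), which means no expected step beyond the scatter. For compound 3 the estimated value is 3500 nM, with an expected range of 1500 nM to 8000 nM.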

Compound 3, half-maximal inhibitory concentration: 7000 nM
Compound 3: middle estimate off by 2.0-fold (0.30 log units), on the low side; the measured number falls inside the stated range.
By their numbers in this assay, from the lowest: compounds 2, 1 and 3 (each within the scatter of the next).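

In this assay this aromatic carbon has now carried hydrogen, methyl and chloro, and all three compounds lie within the scatter of one another. Chloro in place of methyl gives a 1.8-fold higher number from compound 2 to compound 3 (0.24 log units; within the scatter) and chloro in place of hydrogen gives a 1.2-fold higher number from compound 1 to compound 3 (0.07 log units; within the scatter) as its counterpart, so the reading at this carbon no longer rests on the methyl step alone and neither chloro step separates on this read-out. No supporting evidence is available to account for these small steps or to tie them to any property of the groups.

Still open, from the compounds shown here alone, is whether any group on this carbon can shift the number beyond the scatter, for instance an amine, a carboxylic acid or a longer chain. Also open, going by these compounds, is whether this flat reading would hold with changes elsewhere on the shared core, as all three compounds differ only at this one carbon.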